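A few compounds are considered here, and "the series" means these few. Any claim that something is new, unique, unknown or untested is made for them only; others in the source may bear on it.

Measured so far in an ADME assay on K562 cells (Homo sapiens) for cytotoxicity, with a stated time of 72 h; a lower number here means a stronger inhibitor, a higher number a weaker inhibitor:
- compound 1 `COc1cc(CNc2ncnc3c2ncn3C2CCCCO2)cc(OC)c1OC`: > 100000 nM (a limit)
- compound 2 `COc1cc(CNc2ncnc3c2ncn3C2CCCO2)cc(OC)c1`: > 100000 nM (a limit)

Neither entry is a true number. Compound 2 gives > 100000 nM, which is a limit of the assay, so its position can only be described by that limit. It shares this position with compound 1, and the overall picture is simple: the limit of > 100000 nM in this assay, at which 2 of the 2 values shown sit.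

Compound 3 `COc1cc(CNc2ncnc3c2ncn3C2CCCO2)cc(OC)c1OC` differs from compound 2 in one place: methoxy in place of hydrogen on an aromatic carbon. This puts methoxy in place of hydrogen on an aromatic carbon, ortho to two methoxy groups and para to a large group.

For the measured compounds named here, no pair of measured compounds shows the size of a step in this assay, so this forecast has little to rest on. The expectation is no step beyond the usual scatter, with compound 3 most likely also reported only as a limit. The estimated a number no higher from compound 2 to compound 3 (the limit leaves the size open) is therefore expected to be small. The expected value for compound 3 is 100000 nM, with an estimated range from 40000 nM to 100000 nM.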

Compound 3, half-maximal inhibitory concentration: > 100000 nM
Compound 3 was reported as a limit (the forecaster's own chance of this, stated with the estimate: 85%); the middle value sits exactly at the limit.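

In this assay compound 3 gives > 100000 nM, which is a limit and not a number. No step can be read from compound 2 to compound 3 or from compound 1 to compound 3, as all the values shown are limits: the limit of > 100000 nM in this assay, at which 3 of the 3 values shown sit. The compounds shown leave open whether adding the methoxy group or replacing oxan-2-yl with oxolan-2-yl changes the result in this assay at all.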